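The source may hold more compounds than are shown below. What is called first, only, known or untested is meant among the compounds shown, and "the series" means these compounds.

Measured so far:
compound 1 `CN1CCN(c2cccc(C(=O)/C=C/c3cccc(/C=C/C(=O)NO)n3)c2)CC1` — 380000 nM
compound 2 `O=C(/C=C/c1cccc(/C=C/C(=O)c2ccccc2)n1)NO` — 16000 nM
compound 3 `CN1CCN(c2ccccc2C(=O)/C=C/c2ccc(/C=C/C(=O)NO)nc2)CC1` — 469000 nM

All three were run in a physicochemical assay for solubility, at pH 7.4; on this read-out lower numbers stand for lower solubility and higher numbers for higher solubility. For the measured compounds named here, compound 1 gives 380000 nM and compound 2 gives 16000 nM; the step between them, a 24-fold lower number from compound 1 to compound 2 (1.38 log units; beyond the scatter), is the one change in this set with a measured partner: hydrogen in place of 4-methylpiperazin-1-yl on an aromatic carbon. Compound 3 gives 469000 nM in this assay, and this value and that of compound 1 lie within the scatter of each other. Compound 3 and compound 1 share the same atoms joined differently; the difference between the two cores is not broken down here.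

Compound 4 `O=C(/C=C/c1ccc(/C=C/C(=O)c2ccccc2)cn1)NO` is not yet measured. It derives from compound 3 by hydrogen in place of 4-methylpiperazin-1-yl on an aromatic carbon. Going by the values given here, this is the same kind of change as the one from compound 1 to compound 2, though the surroundings differ: in compound 4 the hydrogen enters ortho to a large group, whereas in compound 2 it enters meta to a large group. Among the compounds with values here, only one measured instance of the change exists, so the expectation rests on a single step.

Within the data shown here, compound 4 is expected to sit well below compound 3 in this assay, the expected step being a 23-fold lower number from compound 3 to compound 4 (1.37 log units; beyond the scatter), because the one measured instance, a 24-fold lower number from compound 1 to compound 2 (1.38 log units; beyond the scatter), was large. For compound 4 the estimated value is 20000 nM, with a range from 6000 nM to 65000 nM to allow for the change of place and the different core.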

Compound 4, solubility: 27000 nM
Estimate against measurement, compound 4: 1.4-fold (0.13 log units) below; the range from low to high includes it.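

In this assay, hydrogen in place of 4-methylpiperazin-1-yl on an aromatic carbon gives a 17-fold lower number from compound 3 to compound 4 (1.24 log units; beyond the scatter), in the same direction as the earlier step, a 24-fold lower number from compound 1 to compound 2 (1.38 log units; beyond the scatter), so in these two cores the change carries over as a large step to a lower number. For the compounds shown here, this does not make a rule for the series: there are only two pairs, and they differ both in the core and in where the group sits, here ortho to a large group, so the part played by the core cannot be separated from the part played by the place. No measurement at hand gives a reason for the step in either pair.

The compounds shown leave open whether the step is specific to 4-methylpiperazin-1-yl or would also appear with another group on the same aromatic carbon, such as morpholin-4-yl, dimethylamino or a carboxylic acid. Also open, as far as these compounds go, is whether a longer chain between the aromatic carbon and the amine would give a step of similar size in both cores.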